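The compounds below may be only part of what the source reports. "The series", "measured", "known", "first", "only" and "open" are said of these compounds alone.

Compound 1 `C#Cc1cn([C@@H]2O[C@H](CO)[C@@H](O)[C@H]2O)c2ncnc(C)c12` gives 5600 nM. Compound 2 `C#Cc1cn([C@@H]2O[C@H](CO)[C@@H](O)[C@H]2O)c2ncnc(NC)c12` reaches only a limit of the assay, > 20000 nM. Compound 3 `CNc1ncnc2c1c(-c1ccsc1)cn2[C@@H]1O[C@H](CO)[C@@H](O)[C@H]1O` likewise reaches only a limit, > 20000 nM.

All three were tested in a functional assay on CCRF-CEM cells (Homo sapiens), read by MTT assay, with a stated time of 72 h; on this read-out higher numbers stand for weaker inhibition and lower numbers for stronger inhibition. Among the measured compounds shown here, two of the three numbers are limits rather than measurements, as the limit of > 20000 nM in this assay, at which 2 of the 3 values shown sit, records, so only one step can be read. From compound 2 to compound 1 the change is methyl in place of methylamino on an aromatic carbon, and it brings an at least 3.5-fold lower number from compound 2 to compound 1 (0.55 log units; beyond the scatter). The cores of compound 2 and compound 3 differ by thiophen-3-yl in place of ethynyl on an aromatic carbon; here the step is a step that the two limits leave unreadable from compound 2 to compound 3, since both compounds stand at the limit.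

Compound 4 `Cc1ncnc2c1c(-c1ccsc1)cn2[C@@H]1O[C@H](CO)[C@@H](O)[C@H]1O` has not been measured. It differs from compound 3 by methyl in place of methylamino on an aromatic carbon. This is the same change that separates compound 2 from compound 1, and the place is described in identical words in both cases. For the measured compounds named here, since compound 3 itself is only a limit, the starting point for compound 4 is uncertain, but on the one readable instance of this change, compound 1 against compound 2, a lowering of the number is expected; the step from compound 3 to compound 4 is estimated at an at least 2.2-fold lower number from compound 3 to compound 4 (0.34 log units; beyond the scatter). Compound 4 is therefore expected to give about 9000 nM in this assay, most plausibly between 2500 nM and 30000 nM, with a real chance that it too returns only a limit.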

Compound 4, half-maximal inhibitory concentration: 11200 nM
The estimate for compound 4 lay 1.2-fold (0.09 log units) below the measured number, within the range that was stated.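

Compound 4 puts methyl in place of methylamino on a second core in this assay, and the two cases can now be set side by side: the same change on two cores in this assay, an at least 3.5-fold lower number (0.55 log units; beyond the scatter) from compound 2 to compound 1 and an at least 1.7-fold lower number (0.25 log units; that floor lies within the scatter) from compound 3 to compound 4; the limit leaves it open whether they differ.

From the compounds shown here alone, the direction seen with the ethynyl compounds is therefore not contradicted on the thiophen-3-yl core, but the second pair offers only an at least 1.7-fold lower number from compound 3 to compound 4 (0.25 log units; that floor lies within the scatter), which on its own does not establish a lowering there, and the size of the change on either core stays unknown. For compound 3 the value is only a limit, as it is for compound 2, so the two pairs give floors rather than sizes that could be compared: the limit of > 20000 nM in this assay, at which 2 of the 4 values shown sit.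

Going by these compounds, it remains open how much thiophen-3-yl and ethynyl differ, since with methyl on the ring the exchange gives a 2.0-fold higher number from compound 1 to compound 4 (0.30 log units; within the scatter), while with methylamino it cannot be read, both compounds standing at a limit. The compounds shown also leave open whether another group on that aromatic carbon, such as methoxy, a chlorine atom or a longer chain, would read like methyl or like methylamino on either core.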